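Fluoro added to the methoxy analogue of a diaryl ether series

The source may hold more compounds than are shown below. What is called first, only, known or untested is meant among the compounds shown, and "the series" means these compounds.

Measured compounds:
compound 1, `CCOC(=O)c1ccc(Oc2ccc(C#N)cc2)cc1`, in a functional assay on HL-60 cells (Homo sapiens) for antiproliferative activity (a lower number here means a stronger inhibitor, a higher number a weaker inhibitor), gives > 20000 nM, a limit of the assay.
compound 2, `CCOC(=O)c1ccc(Oc2ccc(N(C)C)cc2)cc1`, gives > 20000 nM, a limit.
compound 3, `CCOC(=O)c1ccc(Oc2ccc(OC)cc2)cc1`, gives > 20000 nM, a limit.

All three measured compounds sit at the limit of > 20000 nM in this assay, at which 3 of the 3 values shown sit, so no number is known for any of them. The step from compound 1 to compound 2 is a step that the two limits leave unreadable from compound 1 to compound 2; that from compound 1 to compound 3 is a step that the two limits leave unreadable from compound 1 to compound 3; and that from compound 2 to compound 3 is a step that the two limits leave unreadable from compound 2 to compound 3. None of these three steps has a readable size, and compound 3 stands only at a limit.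

The next compound, compound 4, `CCOC(=O)c1ccc(Oc2ccc(OC)c(F)c2)cc1`, differs from compound 3 by fluoro in place of hydrogen on an aromatic carbon. Among the measured compounds shown here, no measured step bears on this change directly, and the three steps that exist are all unreadable. For the measured compounds named here, the only evidence is that compound 3 gives a limit in this assay, so the working expectation is that compound 4 will again report only a limit, with no change of readable size.

For compound 4 the expected step is a step that the limit leaves unreadable from compound 3 to compound 4, and the estimate is 25000 nM, with a range from 6000 nM to 100000 nM.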

Compound 4, half-maximal inhibitory concentration: 3500 nM
Compound 4: middle estimate off by 7.1-fold (0.85 log units), on the high side; measured number outside the range, below it.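

In this assay, fluoro in place of hydrogen, on an aromatic carbon ortho to a methoxy group and meta to a large group, gives a step that can be sized at least in part: an at least 5.7-fold lower number from compound 3 to compound 4 (0.75 log units; beyond the scatter). Among the compounds shown here, the steps among compound 1, compound 2 and compound 3 cannot be read, so this is the first sign that a change on this ring can move the read-out, and that a single added fluorine atom is enough to do so here. The true size of the step stays unknown, because compound 3 stands only at a limit of the assay: the limit of > 20000 nM in this assay, at which 3 of the 4 values shown sit.

From the compounds shown here alone, it remains open whether the gain belongs to fluoro alone or would also appear with chloro or a hydroxyl group on the same carbon, and whether fluoro would give a readable number alongside the nitrile of compound 1 or the dimethylamino group of compound 2. Also open, going by these compounds, is how a carboxylic acid in place of the ethyl ester would read in this assay.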